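This account rests on a few compounds, and the source may have more. Where it says the series, first, only, none or still open, it means among the compounds named here.

Measured compounds and their values:

Compound 1, `O=S(=O)(c1ccccc1)c1nc2ccccc2nc1Nc1ccc(Cl)cc1`: 15300 nM
Compound 2, `COc1ccc(S(=O)(=O)c2nc3ccccc3nc2Nc2ccc(Cl)cc2)cc1`: 31800 nM
Compound 3, `O=S(=O)(c1ccc(Br)cc1)c1nc2ccccc2nc1Nc1ccccc1`: 1180 nM

The three compounds were measured in a functional assay on PC-3 cells (Homo sapiens) for cytotoxicity, read by MTT assay, with a stated time of 72 h; on this read-out higher numbers stand for weaker inhibition and lower numbers for stronger inhibition. Compound 1 gives 15300 nM, and compound 2 gives 31800 nM. Compound 3 gives 1180 nM, the lowest of the three; its nearest neighbour by value is compound 1, and compound 2 stands furthest from it. How the core of compound 3 differs from that of compound 1 is not broken down here.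

One structural change occurs twice among these compounds. From compound 1 to compound 2 the change is methoxy in place of hydrogen on an aromatic carbon, and in this assay it gave a 2.1-fold higher number from compound 1 to compound 2 (0.32 log units; beyond the scatter). Compound 4, `COc1ccc(Nc2nc3ccccc3nc2S(=O)(=O)c2ccc(Br)cc2)cc1`, has not yet been measured. Going by the values given here, from compound 3 to compound 4 the change is methoxy in place of hydrogen on an aromatic carbon, and the difference cut one bond further out reads phenyl to 4-methoxyphenyl and anilino to (4-methoxyphenyl)amino; it is the same change as the one from compound 1 to compound 2.

Given that the one measured step from compound 1 to compound 2 was a 2.1-fold higher number from compound 1 to compound 2 (0.32 log units; beyond the scatter), a step of about the same size is expected from compound 3 to compound 4, namely a 2.1-fold higher number from compound 3 to compound 4 (0.33 log units; beyond the scatter). Among the compounds with values here, on that basis compound 4 is estimated at 2500 nM in this assay, with a range from 1000 nM to 6500 nM expected, because only a single measured instance of this change, a 2.1-fold higher number from compound 1 to compound 2 (0.32 log units; beyond the scatter), supports the estimate.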

Compound 4, half-maximal inhibitory concentration: 1110 nM
For compound 4 the middle estimate is 2.3-fold (0.35 log units) above the measured one; low and high end bracket the measured number.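

In this assay, methoxy in place of hydrogen on an aromatic carbon gave a 1.1-fold lower number from compound 3 to compound 4 (0.03 log units; within the scatter), so on this core the change leaves the value indistinguishable from that of the unsubstituted parent. Set beside the earlier step, the two results do not differ measurably, which means the data give no sign that the core alters the effect of this change: the same change on two cores in this assay, a 2.1-fold higher number (0.32 log units; beyond the scatter) from compound 1 to compound 2 and a 1.1-fold lower number (0.03 log units; within the scatter) from compound 3 to compound 4, 2.2-fold (0.34 log units) apart, within the scatter of two such steps. Going by these compounds alone, this does not show that the change carries over with a fixed size, since it rests on only two steps, one of them beyond the scatter and the other within it, and the methoxy enters a different aromatic ring in each pair, so the ring that takes the group cannot be separated from the rest of the core.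

The compounds shown leave open how the chloro and bromo substituents each contribute, as compound 1 and compound 3 differ in more than one place. They also leave open whether an amine, a carboxylic acid or a longer alkoxy chain in place of the methoxy would behave as the methoxy does, and whether methoxy at another ring position would give the same result.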